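The source may hold more compounds than are shown below. What is called first, only, known or untested is meant among the compounds shown, and "the series" means these compounds.

In a functional assay on MCF cells (Homo sapiens) for antiproliferative activity, with a stated time of 72 h (a higher number here means a weaker inhibitor, a lower number a stronger inhibitor), compound 1 `Cc1cccc(CNc2ncnc3c2ncn3[C@@H]2O[C@H](CO)[C@@H](O)[C@H]2O)c1` gives only a limit, > 166000 nM. Compound 2 `COc1ccc(CNc2ncnc3c2ncn3[C@@H]2O[C@H](CO)[C@@H](O)[C@H]2O)c(OC)c1` also gives only a limit, > 166000 nM, and so stands at the limit of > 166000 nM in this assay, at which 2 of the 2 values shown sit. Going by the values given here, the only measured step, a step that the two limits leave unreadable from compound 1 to compound 2, gives no size or direction to carry forward. Compound 3 `OC[C@H]1O[C@@H](n2cnc3c(NCc4cccc(O)c4O)ncnc32)[C@H](O)[C@@H]1O` differs from compound 2 by 2,3-dihydroxyphenyl in place of 2,4-dimethoxyphenyl on a saturated chain carbon bound to a nitrogen on an aromatic ring, with 2,3-dihydroxyphenyl entering in place of 2,4-dimethoxyphenyl. With no readable step as a guide, only a small change, if any, is expected in this assay. The estimated change is an at least 1.1-fold lower number from compound 2 to compound 3 (0.04 log units; that floor lies within the scatter). For compound 3 the expected value is 150000 nM, with an estimated range of 40000 nM to 250000 nM.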

Compound 3, half-maximal inhibitory concentration: 5200 nM
For compound 3 the middle estimate is 29-fold (1.46 log units) above the measured one; the whole stated range lies above it.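

The position on a saturated chain carbon bound to a nitrogen on an aromatic ring is not silent in this assay: 2,3-dihydroxyphenyl gives an at least 31-fold lower number from compound 2 to compound 3 (1.50 log units; beyond the scatter) and an at least 31-fold lower number from compound 1 to compound 3 (1.50 log units; beyond the scatter). Compound 1 and compound 2 both stay at a limit, so these steps are floors and the step between those two cannot be read: the limit of > 166000 nM in this assay, at which 2 of the 3 values shown sit.

From the compounds shown here alone, compound 3 changes both the substituents and their ring positions relative to compound 2, so it remains open which of these carries the step. A 2,3-dimethoxyphenyl or a single 3-hydroxyphenyl group at this place would separate the two.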